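The compounds below may be only part of what the source reports. "The series", "measured", "known", "first", "only" and "open" are said of these compounds alone.

Compound 1 `O=C(Nc1cc(C(F)(F)F)cc(C(F)(F)F)c1)C1CCc2ccccc2N1C(=O)c1ccccc1Cl` belongs to a small set of amides built on a shared core, tested in a functional assay on PC-3 cells (Homo sapiens) for cytotoxicity, read by sulforhodamine B assay, with a stated time of 72 h; a higher number here means a weaker inhibitor of growth, a lower number a stronger inhibitor of growth. In this assay compound 1 gives 8040 nM, the higher of the two numbers reported. Its nearest neighbour is compound 3 `O=C(Nc1ccccc1C(F)(F)F)C1CCc2ccccc2N1C(=O)c1ccccc1`, which gives 5560 nM; the two values lie within the scatter of this assay, so neither can be called the stronger inhibitor. Compound 2 `O=C(Nc1ccc(O)cc1)C1CCc2ccccc2N1` is reported only as a limit, > 100000 nM, and gives no number. This is the case described by the limit of > 100000 nM in this assay, at which 1 of the 3 values shown sits.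

Compound 4 `CCC(=O)N1c2ccccc2CCC1C(=O)Nc1cc(C(F)(F)F)cc(C(F)(F)F)c1` has not yet been measured. It differs from compound 1 at one place: ethyl in place of 2-chlorophenyl on a carbonyl carbon. Among the measured compounds shown here, no measured pair shows this exact change, so its effect must be judged from what the three measured compounds show. The two compounds that carry a carbonyl group on the ring nitrogen, compound 1 and compound 3, both give numbers, while compound 2, which carries none, gives only a limit. Keeping the carbonyl but shrinking the group on it is expected to weaken growth inhibition modestly, so compound 4 is expected to give 18000 nM, between 5000 nM and 70000 nM, a step of a 2.2-fold higher number from compound 1 to compound 4 (0.35 log units; beyond the scatter) that is estimated to reach just beyond the scatter.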

Compound 4, concentration for 50% growth inhibition: 8540 nM
Compound 4: middle estimate off by 2.1-fold (0.32 log units), on the high side, within the range that was stated.
By their numbers in this assay, from the lowest: compounds 3, 1 and 4 (each within the scatter of the next). At a limit, above all of these: compound 2.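

Replacing the 2-chlorophenyl on this carbonyl carbon with ethyl gives a 1.1-fold higher number from compound 1 to compound 4 (0.03 log units; within the scatter), so in this assay the two compounds cannot be told apart. A whole aromatic ring and its chlorine leave, only a two-carbon group enters, and the read-out does not register a difference, so for this pair the ring is not required for the modest growth inhibition seen. None of the measurements shown explains why the two groups give such similar numbers, and this remains an observation on a single pair.

Going by these compounds, with only these two groups to compare at this position, it remains open whether an amine, a carboxylic acid or a longer chain on the same carbonyl carbon would also leave the number in this assay in the same range. Compound 2, whose > 100000 nM is a limit and not a number, has no carbonyl group on the ring nitrogen but also differs from the other compounds in its other amide, so it cannot show what removing the whole acyl group would do.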